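Swapping an Arylamine for a Butoxy-Bearing Piperidine

This account rests on a few compounds, and the source may have more. Where it says the series, first, only, none or still open, it means among the compounds named here.

Three measured compounds share one core and were tested in a functional assay on CHO-K1 cells for antagonist activity at transient receptor potential cation channel subfamily V member 1 (Homo sapiens), read by FLIPR; a higher number here means a weaker inhibitor, a lower number a stronger inhibitor. Compound 1 `Cc1ccc(Nc2nc(C(F)(F)F)ccc2CNC(=O)C(C)c2ccc(NS(C)(=O)=O)c(F)c2)cc1C` gives 39.3 nM. Compound 3 `COC1CCN(c2nc(C(F)(F)F)ccc2CNC(=O)C(C)c2ccc(NS(C)(=O)=O)c(F)c2)CC1` gives 2.4 nM, and compound 2 `Cc1ccc(CC2CCN(c3nc(C(F)(F)F)ccc3CNC(=O)C(C)c3ccc(NS(C)(=O)=O)c(F)c3)CC2)cc1` gives 0.2 nM. Compound 1 therefore has the highest number of the three and is the weakest inhibitor of the set; its nearest neighbour is compound 3, and the step of a 16-fold lower number from compound 1 to compound 3 (1.21 log units; beyond the scatter) is large, while compound 2 lies furthest from it.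

Compound 4 `CCCCOC1CCN(c2nc(C(F)(F)F)ccc2CNC(=O)C(C)c2ccc(NS(C)(=O)=O)c(F)c2)CC1` has not yet been measured. It differs from compound 1 in one place: a group of 11 heavy atoms (9 carbon, 1 nitrogen, 1 oxygen; one six-membered non-aromatic ring with 1 hetero atom) in place of a group of 9 heavy atoms (8 carbon, 1 nitrogen; one six-membered aromatic ring of carbon only), on an aromatic carbon.

Going by the values given here, two measured steps bear on this. The step of a 16-fold lower number from compound 1 to compound 3 (1.21 log units; beyond the scatter) is the same kind of exchange at the same place, except that the group entering compound 4 carries a butoxy chain rather than a methoxy. The step of a 12-fold higher number from compound 2 to compound 3 (1.08 log units; beyond the scatter) shows that what sits on the saturated ring carbon of that ring can shift the number by a large amount in this assay. A large downward step is therefore expected for compound 4, estimated as a 39-fold lower number from compound 1 to compound 4 (1.59 log units; beyond the scatter). Compound 4 is expected to give about 1 nM, with a likely range from 0.3 nM to 4 nM.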

Compound 4, inhibition constant: 3.5 nM
The estimate for compound 4 lay 3.5-fold (0.54 log units) below the measured number; low and high end bracket the measured number.
By their numbers in this assay, from the lowest: compound 2; then compounds 3 and 4 (each within the scatter of the next); then compound 1.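

In this assay, the large fall seen with the methoxy-bearing piperidine also holds with a butoxy chain on that ring, with an 11-fold lower number from compound 1 to compound 4 (1.05 log units; beyond the scatter) at the aromatic carbon next to the ring nitrogen. Extending the chain makes no clear difference: a 1.5-fold higher number from compound 3 to compound 4 (0.16 log units; within the scatter) stays within the scatter, so compounds 3 and 4 cannot be told apart in this assay. The butoxy chain also does not match the 4-methylbenzyl group on the saturated ring carbon, as an 18-fold higher number from compound 2 to compound 4 (1.24 log units; beyond the scatter) shows, so the large shift seen earlier at that carbon does not appear with a longer saturated chain alone.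

Nothing measured here explains why these steps have the sizes they do. The compounds shown leave open whether a benzyloxy group or a chain ending in an amine or a carboxylic acid on that ring carbon would come closer to compound 2, and whether a morpholine or an open-chain dialkylamine at the aromatic carbon would give the same large fall from compound 1.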